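Tolerance of a cyclopentyl amide on Huh-7 cells

The source may report more compounds than this note shows. Statements on the series, on what has been measured and on what is new or still open speak of the compounds shown alone.

Compounds measured so far:
Compound 1, `CC(C)(C)C(=O)N(CCCCCCN1C[C@H](O)[C@@H](O)[C@H](O)[C@H]1CO)C1CCCCC1`: 500000 nM
Compound 2, `CC(=O)N(CCCCCCN1C[C@H](O)[C@@H](O)[C@H](O)[C@H]1CO)C1CCCCC1`: > 500000 nM
Compound 3, `CC(C)(C)C(=O)N(CCCCCCN1C[C@H](O)[C@@H](O)[C@H](O)[C@H]1CO)c1cc(F)ccc1F`: > 500000 nM

All three share one core and differ only at the amide-type nitrogen or its carbonyl. In an ADME assay on Huh-7 cells (Homo sapiens) for cytotoxicity, read by MTT assay (a lower number here means that less compound is tolerated, a higher number that more compound is tolerated), compound 1 gives 500000 nM. For compound 2 the result is only a limit of this assay, > 500000 nM. For compound 3 the result is likewise only a limit, > 500000 nM; so compound 3 stands at the edge of what this assay reports, together with compound 2, as the limit of > 500000 nM in this assay, at which 2 of the 3 values shown sit, shows. The two steps from compound 1, a number no lower from compound 1 to compound 2 (the limit leaves the size open) and a number no lower from compound 1 to compound 3 (the limit leaves the size open), are of unreadable size.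

Compound 4, `CC(C)(C)C(=O)N(CCCCCCN1C[C@H](O)[C@@H](O)[C@H](O)[C@H]1CO)C1CCCC1`, differs from compound 3 by cyclopentyl in place of 2,5-difluorophenyl on an amide-type nitrogen. Within the data shown here, no measured step swaps this pair of groups, but compound 1 carries cyclohexyl, a close relative of cyclopentyl, on the same nitrogen and sits at 500000 nM. The expected step of a number no higher from compound 3 to compound 4 (the limit leaves the size open) is therefore no more than the scatter. Compound 4 is expected to give 500000 nM, within 250000 nM to 1000000 nM.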

Compound 4, half-maximal cytotoxic concentration: > 500000 nM
Compound 4: no number, only a limit; the forecaster's own chance of this, stated with the estimate: 50%; the middle value sits exactly at the limit.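

Compound 4 gives > 500000 nM in this assay, which is a limit of the assay and not a number. With cyclopentyl in place of cyclohexyl on the amide-type nitrogen, the result is a number no lower from compound 1 to compound 4 (the limit leaves the size open). This shows that the amide-type nitrogen can carry cyclopentyl, a five-membered non-aromatic ring, and the value still sits at that limit, as it does with the 2,5-difluorophenyl of compound 3; the size of neither new step can be read. The result adds one more compound at the edge of what is reported: the limit of > 500000 nM in this assay, at which 3 of the 4 values shown sit.

On these data alone, how compound 2, compound 3 and compound 4 would compare with a wider measuring range stays open, as none of them has a number. Also open, as far as these compounds go, is whether an isopropyl group, or a cyclopentyl ring carrying an amine, on this nitrogen would give a readable value.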